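Swapping the Phenyl Group on a Non-Cytotoxic Series

The compounds below may be only part of what the source reports. "The series", "measured", "known", "first", "only" and "open" are said of these compounds alone.

In a functional assay on HEK293 cells (Homo sapiens) for cytotoxicity (a higher number here means that more compound is tolerated, a lower number that less compound is tolerated), compound 1 (`COc1ccc([C@H]2CC(=O)N(c3cc(N)cc(F)c3)C2)cc1OC1CCCC1`) gives > 10000 nM, which is a limit of the assay and not a number. Compound 2 (`COc1ccc([C@H]2CC(=O)N(c3ccc(C)cc3)C2)cc1OC1CCCC1`) gives > 10000 nM, which is likewise a limit and not a number. Among the measured compounds shown here, compound 2 therefore offers no exact value, and its position is shared by the only other compound measured: the limit of > 10000 nM in this assay, at which 2 of the 2 values shown sit.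

Compound 3 (`COc1ccc([C@H]2CC(=O)N(c3cccc(C(F)(F)F)c3)C2)cc1OC1CCCC1`) keeps the shared core of compound 2 and changes one group: 3-(trifluoromethyl)phenyl in place of 4-methylphenyl on an amide-type nitrogen in a ring. For the measured compounds named here, one measured step bears on this change, a step that the two limits leave unreadable from compound 1 to compound 2, as it also exchanges the phenyl group on the amide-type nitrogen in a ring. Its size cannot be read, so it offers no size to carry over and no direction. With nothing pointing to a real shift, no change beyond the scatter is expected in this assay, and a result reported only as a limit is the likeliest outcome. The expected step is a step that the limit leaves unreadable from compound 2 to compound 3. The half-maximal cytotoxic concentration estimated for compound 3 is 15000 nM, with an expected range from 6000 nM to 50000 nM.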

Compound 3, half-maximal cytotoxic concentration: > 10000 nM
Compound 3 was reported as a limit; the forecaster's own chance of this, stated with the estimate: 85%; the middle value does not contradict the limit.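

In this assay compound 3 gives > 10000 nM, which is a limit and not a number. No step from compound 1 or compound 2 to compound 3 can be read, and all three compounds share one position: the limit of > 10000 nM in this assay, at which 3 of the 3 values shown sit.

The compounds shown leave open whether exchanging the phenyl group on the amide-type nitrogen changes the half-maximal cytotoxic concentration at all.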